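Removing the Trifluoromethyl Group from Compound 2

The source may hold more compounds than are shown below. What is called first, only, known or untested is meant among the compounds shown, and "the series" means these compounds.

Compound 2 `FC(F)(F)c1ccc(Nc2cncc(N3CC4CC(C3)N4)c2)cc1` gives 1.02 nM in an assay on HEK293 cells for displacement of a labelled ligand from Neuronal acetylcholine receptor; alpha3/beta4 (Homo sapiens); on this read-out lower numbers stand for stronger inhibition and higher numbers for weaker inhibition. Compound 1 `Oc1ccc(Nc2cncc(N3CC4CC(C3)N4)c2)cc1` gives 0.988 nM in this assay, so the two numbers sit within the scatter of each other, as a 1.0-fold higher number from compound 1 to compound 2 (0.01 log units; within the scatter) shows. Compound 3 `c1ccc(Nc2cncc(N3CC4CC(C3)N4)c2)cc1` carries the change (hydrogen in place of trifluoromethyl on an aromatic carbon). Within the data shown here, only the step from compound 1 to compound 2 bears on this change, and because a 1.0-fold higher number from compound 1 to compound 2 (0.01 log units; within the scatter) stayed within the scatter, no step beyond the scatter is expected for compound 3 either. Compound 3 is estimated at 1 nM, with a range from 0.4 nM to 2.5 nM. This estimate means a step of a 1.0-fold lower number from compound 2 to compound 3 (0.01 log units; within the scatter).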

Compound 3, inhibition constant: 0.799 nM
For compound 3 the middle estimate is 1.3-fold (0.10 log units) above the measured one; the measured number falls inside the stated range.
By their numbers in this assay, from the lowest: compounds 3, 1 and 2 (each within the scatter of the next).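

Compound 3 adds the case of no substituent at all at this position: hydrogen gives a 1.3-fold lower number from compound 2 to compound 3 (0.11 log units; within the scatter) and a 1.2-fold lower number from compound 1 to compound 3 (0.09 log units; within the scatter) in this assay. Trifluoromethyl, hydroxy and hydrogen therefore cannot be told apart here, so neither group is needed to reach this level of binding. Going by these compounds, whether the same would hold for an amine, a carboxylic acid or a longer chain at this position remains open. No measurement available here explains why these three compounds read alike.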